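The compounds below may be only part of what the source reports. "The series", "measured", "known", "first", "only" and "open" are said of these compounds alone.

Measured in an assay on HEK293 cells for agonist activity at transient receptor potential cation channel subfamily M member 8 (Homo sapiens), read by fluorescence and calcium flux, with a stated time of 5 min; on this read-out higher numbers stand for an effect only at larger amounts of compound and lower numbers for an effect already at smaller amounts:
compound 1 `C=CCc1cc(OC)c(O[C@H](C)[C@@H](OCC)c2ccc(O)c(OC)c2)c(OC)c1` gives 1150 nM
compound 2 `C=CCc1cc(OC)c(OC(C)C(OCC(C)C)c2ccc(O)c(OC)c2)c(OC)c1` gives 138 nM
compound 3 `C=CCc1cc(OC)c(O[C@H](C)[C@H](OCC)c2ccc(O)c(OC)c2)c(OC)c1` gives 583 nM

Compound 2 holds the lowest number of the three, with both other compounds beyond the scatter above it. Among the compounds with values here, the only single-place step measured, a 2.0-fold lower number from compound 1 to compound 3 (0.30 log units; within the scatter), rests on a change of configuration alone the fact that compounds 1 and 3 differ only in the configuration as drawn and does not speak to the present change. Compound 4 `C=CCc1cc(OC)c(OC(C)C(OC)c2ccc(O)c(OC)c2)c(OC)c1` differs from compound 2 by hydrogen in place of isopropyl on a saturated chain carbon bound to an oxygen on a saturated carbon. Compounds 1 and 3 also carry a different group from compound 2 on the saturated chain carbon bound to an oxygen on a saturated carbon, besides their fixed configuration, and both give higher numbers than compound 2, so a move in the same direction is expected here. The step expected is a 5.1-fold higher number from compound 2 to compound 4 (0.71 log units; beyond the scatter). Compound 4 is estimated at 700 nM, range 250 nM to 2000 nM.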

Compound 4, half-maximal effective concentration: 3450 nM
Compound 4: the middle estimate sits 4.9-fold (0.69 log units) below what was measured; measured number outside the range, above it.
By their numbers in this assay, from the lowest: compound 2; then compounds 3 and 1 (each within the scatter of the next); then compound 4.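

In this assay the change from isobutoxy to methoxy gives a 25-fold higher number from compound 2 to compound 4 (1.40 log units; beyond the scatter), so the group at this place, on a saturated chain carbon bound to an oxygen on a saturated carbon, is not a silent part of the series. The step is large, and compound 2, with the isobutoxy group, keeps the lowest number. No measured finding at hand bears on the cause of this step.

As far as these compounds go, whether a longer chain, such as hexyloxy, or a benzyloxy group at this place would bring the number lower remains open. So does the outcome of an amine on this chain, and of fixed configuration in compound 2.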